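Three Ester Variants and a Doubly Acylated Analogue

The source may report more compounds than this note shows. Statements on the series, on what has been measured and on what is new or still open speak of the compounds shown alone.

Compound 1, `COc1cc2c(c(O)c1C(=O)/C=C/c1ccc(OC(=O)c3ccc(Cl)nc3)cc1)CCC(C)(C)O2`: in an assay on HEK293T cells for inhibition of nuclear factor NF-kappa-B complex (Homo sapiens), read by a luciferase reporter (a higher number here means a weaker inhibitor, a lower number a stronger inhibitor), compound 1 gives > 30000 nM, a limit of the assay.
Compound 2, `C=CCOC(=O)Oc1ccc(/C=C/C(=O)c2c(OC)cc3c(c2O)CCC(C)(C)O3)cc1`: in this assay compound 2 gives > 30000 nM, again a limit.
Compound 3, `COc1cc2c(c(O)c1C(=O)/C=C/c1ccc(OC(=O)c3cccc(Br)c3)cc1)CCC(C)(C)O2`: in this assay compound 3 gives > 30000 nM, also a limit.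

Compound 3 therefore stands at the edge of what the assay can report, where all three measured compounds sit (the limit of > 30000 nM in this assay, at which 3 of the 3 values shown sit). No number is known for any of them.

Compound 4, `COc1cc2c(c(OC(=O)c3cccc(Br)c3)c1C(=O)/C=C/c1ccc(OC(=O)c3cccc(Br)c3)cc1)CCC(C)(C)O2`, differs from compound 3 in one place: (3-bromophenyl)carbonyl in place of hydrogen on an oxygen on an aromatic ring. The measured steps all change the group on the carbonyl carbon of the ester on the other ring, and none of them is readable: a step that the two limits leave unreadable from compound 1 to compound 3, a step that the two limits leave unreadable from compound 2 to compound 3 and a step that the two limits leave unreadable from compound 1 to compound 2. Among the measured compounds shown here, none touches the oxygen on the aromatic ring of the shared core where compound 4 is changed, so no measured step bears directly on this change.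

With every neighbour at the limit, compound 4 is expected to stay at the limit as well, a step that the limit leaves unreadable from compound 3 to compound 4 in this assay. The estimate for compound 4 is 40000 nM, within 15000 nM to 150000 nM.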

Compound 4, half-maximal inhibitory concentration: > 30000 nM
Compound 4 was reported as a limit; the forecaster's own chance of this, stated with the estimate: 85%; the middle value does not contradict the limit.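

In this assay compound 3 and compound 4 both stand at a limit, so the size of the step between them cannot be read. The compounds shown leave open how strongly each one inhibits, and which change to the shared core, if any, would give a measurable value.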